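This account rests on a few compounds, and the source may have more. Where it says the series, first, only, none or still open, it means among the compounds named here.

Measured so far:
compound 1 `COc1ncc(-c2ccc3nc(NC(C)=O)nn3c2)cc1NS(=O)(=O)c1ccc(F)cc1` — 1820 nM
compound 2 `COc1ncc(-c2ccc3nc(N)nn3c2)cc1NS(=O)(=O)c1ccc(F)cc1` — 3950 nM
compound 3 `COc1ncc(-c2ccn3nc(NC(C)=O)nc3c2)cc1NS(=O)(=O)c1ccc(F)cc1` — 2410 nM

In a functional assay on U-87MG ATCC cells (Homo sapiens) for antiproliferative activity, read by MTT assay, with a stated time of 48 h (a lower number here means a stronger inhibitor, a higher number a weaker inhibitor), compound 1 gives 1820 nM, compound 2 gives 3950 nM and compound 3 gives 2410 nM. The change from compound 1 to compound 2 is hydrogen in place of acetyl on a nitrogen on an aromatic ring and it made a step of a 2.2-fold higher number from compound 1 to compound 2 (0.34 log units; beyond the scatter). Compound 1 and compound 3 carry the same atoms joined differently; the difference between the two cores is not broken down here, and their values in this assay sit within the scatter of each other.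

Compound 4 `COc1ncc(-c2ccn3nc(N)nc3c2)cc1NS(=O)(=O)c1ccc(F)cc1` is not yet measured. From compound 3 it differs by hydrogen in place of acetyl on a nitrogen on an aromatic ring, the same change as from compound 1 to compound 2, at the same kind of place. The step is expected to resemble a 2.2-fold higher number from compound 1 to compound 2 (0.34 log units; beyond the scatter), so an estimated 2.2-fold higher number from compound 3 to compound 4 (0.34 log units; beyond the scatter) is assumed because of a 2.2-fold higher number from compound 1 to compound 2 (0.34 log units; beyond the scatter). Compound 4 is thus expected to give about 5300 nM in this assay, estimated between 2600 nM and 11000 nM.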

Compound 4, half-maximal inhibitory concentration: 1770 nM
Compound 4: the middle estimate sits 3.0-fold (0.48 log units) above what was measured; the whole stated range lies above it.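

In this assay, the exchange of acetyl for hydrogen does not carry over unchanged from one core to the other: the same change on two cores in this assay, a 2.2-fold higher number (0.34 log units; beyond the scatter) from compound 1 to compound 2 and a 1.4-fold lower number (0.13 log units; within the scatter) from compound 3 to compound 4, 3.0-fold (0.47 log units) apart, beyond the scatter of two such steps. On the second core, the same exchange gives a 1.4-fold lower number from compound 3 to compound 4 (0.13 log units; within the scatter), so the step seen on the core of compound 1 cannot be assumed to apply to other cores in this series. With a single pair on each core, these data show that the step depends on the core but not which feature of the core is responsible.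

Going by these compounds, it remains open how the two cores respond to other groups on that nitrogen, such as a propanoyl group, a longer acyl chain or a methyl group. On these data alone, it is also open whether the gap between the steps persists with chlorine in place of the fluorine.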